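The source may report more compounds than this note shows. Statements on the series, on what has been measured and on what is new or still open speak of the compounds shown alone.

Of the compounds shown here, three have been read in an ADME assay on MT4 cells (Homo sapiens) for cytotoxicity, read by MTT assay; on this read-out lower numbers stand for higher toxicity in this test and higher numbers for lower toxicity in this test. In this assay, compound 1 `O=C1c2ccccc2C(=O)N1CCOC(=S)N(C(=O)c1ccc(C(F)(F)F)cc1)c1ccc(Cl)cc1` gives 10000 nM, the lowest of the numbers available. The nearest value comes from compound 3 `O=C1c2ccccc2C(=O)N1CCOC(=S)N(C(=O)c1ccc(Cl)c([N+](=O)[O-])c1)c1ccccc1`, at 51000 nM, a gap that lies beyond the usual scatter. Compound 2 `Cc1ccc(N(C(=O)c2cccc(C)c2)C(=S)OCCN2C(=O)c3ccccc3C2=O)cc1` returned only a limit, > 100000 nM, and not a number.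

The compound now awaiting measurement is compound 4 `O=C1c2ccccc2C(=O)N1CCOC(=S)N(C(=O)c1cc(F)cc(F)c1)c1ccc(Cl)cc1`. It differs from compound 1 in a single place, where 3,5-difluorophenyl stands in place of 4-(trifluoromethyl)phenyl on a carbonyl carbon whose other neighbour is the amide-type nitrogen: 3,5-difluorophenyl in place of 4-(trifluoromethyl)phenyl on a carbonyl carbon. No measured pair among these compounds isolates a change of this kind, so the size of the step can only be judged from the spread of the readings. With compound 1 at the low end at 10000 nM, a change at this place seems more likely to raise the number than to lower it. The expected change is a 2.2-fold higher number from compound 1 to compound 4 (0.34 log units; beyond the scatter), an estimated upward move towards lower toxicity in this assay that may only just clear the scatter. For compound 4 the estimated half-maximal cytotoxic concentration is 22000 nM, within an expected range of 7000 nM to 70000 nM.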

Compound 4, half-maximal cytotoxic concentration: 59000 nM
The estimate for compound 4 lay 2.7-fold (0.43 log units) below the measured number, within the range that was stated.
By their numbers in this assay, from the lowest: compound 1; then compounds 3 and 4 (each within the scatter of the next). At a limit, above all of these: compound 2.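

In this assay, placing 3,5-difluorophenyl in place of 4-(trifluoromethyl)phenyl on a carbonyl carbon gives a 5.9-fold higher number from compound 1 to compound 4 (0.77 log units; beyond the scatter), a move towards lower toxicity in this test. The earlier compounds shown here differed from one another in more than one place, so none of them could tie a shift to this position; this pair shows that, with the rest of the core of compound 1 held fixed, a change at this one place is enough to carry the read-out beyond the scatter. Nothing shown here accounts for the step, so it remains open whether it follows from the loss of the trifluoromethyl group or from the two fluorines that enter.

This single pair does not show whether a simple phenyl, a 4-fluorophenyl or a ring bearing an amine or a carboxylic acid on this carbonyl would move the number in the same direction. It also leaves open whether the same exchange gives a step of similar size when the group on the amide-type nitrogen is changed.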